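The compounds below may be only part of what the source reports. "The series", "measured", "known", "first", "only" and "open" are said of these compounds alone.

Working notes on the series. Compound 1 `Oc1cccc(-c2cc(-c3cccnc3)nc(-c3cccc(Cl)c3)c2)c1` stands in a functional assay on HCT-15 cells (Homo sapiens) for cytotoxicity, read by CCK-8 assay and cell counting, with a stated time of 2 days (a lower number here means a stronger inhibitor, a higher number a weaker inhibitor), without a single number; its result is recorded as "not determined" (no result reported). Compound 2 `Oc1cccc(-c2cc(-c3cccnc3)nc(-c3ccccc3Cl)c2)c1`, a close relative that differs only in the placement of the chlorine on its phenyl ring, likewise has no number in this assay; the result for compound 2 is recorded as "not determined" (no result reported). The only figure in hand comes from compound 3 `Oc1ccc(-c2cc(-c3cccnc3)nc(-c3cccc(Cl)c3)c2)cc1`, an isomer of compound 1 in the placement of the hydroxyl group; in this assay compound 3 gives 21300 nM, which is weak. So compound 1 cannot be placed against anything on the numbers shown, and the series as a whole is anchored by a single weak value.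

The next compound is compound 4 `Oc1cccc(-c2cc(-c3ccsc3)nc(-c3cccc(Cl)c3)c2)c1`. Its change from compound 1 is thiophen-3-yl in place of pyridin-3-yl on an aromatic carbon. For the measured compounds named here, no step between measured compounds exists for this kind of change, and compound 1 itself has no number, so no direction can be read from the data. The working expectation is that compound 4 stays in the same weak region as compound 3, with any shift no larger than the usual scatter of this assay in either direction. On that basis compound 4 is estimated at 20000 nM in this assay, with a range from 5000 nM to 80000 nM, and with a fair chance that only a limit is reported.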

Compound 4, half-maximal inhibitory concentration: 2510 nM
The estimate for compound 4 lay 8.0-fold (0.90 log units) above the measured number, and the stated range ends above it.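

For the compounds shown here, compound 1 has no single number in this assay, so no step to compound 4 can be read from this result. Nothing measured here bears on the result of compound 4. The compounds shown leave open whether thiophen-3-yl in place of pyridin-3-yl changes the value at all.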